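Fluoro for Methyl on a Carbamate Aryl Ring

The source may report more compounds than this note shows. Statements on the series, on what has been measured and on what is new or still open speak of the compounds shown alone.

Compound 1, `N#Cc1ccnc(OC(=O)N2CCC(C(c3ccccc3)c3ccccc3)CC2)c1`, in an assay on isolated protein for inhibition of Fatty-acid amide hydrolase 1 (Rattus norvegicus), read by fluorescence; on this read-out lower numbers stand for stronger inhibition and higher numbers for weaker inhibition: > 1000 nM
Compound 2, `Cc1cc(C#N)cc(OC(=O)N2CCC(C(c3ccccc3)c3ccccc3)CC2)c1`, in this assay: > 1000 nM

The value of compound 1 in this assay is a limit of the assay, not a number. The value of compound 2 in this assay is likewise a limit. Because both values sit at the limit of > 1000 nM in this assay, at which 2 of the 2 values shown sit, the step that the two limits leave unreadable from compound 1 to compound 2 cannot be read, and compound 2 can only be placed at that limit, with no number to rank it by.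

Compound 3, `N#Cc1cc(F)cc(OC(=O)N2CCC(C(c3ccccc3)c3ccccc3)CC2)c1`, is reached from compound 2 by the change (fluoro in place of methyl on an aromatic carbon), a small change in which one heavy atom replaces another on the aromatic ring. No measured step among the compounds shown bears on this change, since the only measured pair gives no readable step. Compound 3 is therefore expected to stay near the limit of compound 2, with a step that the limit leaves unreadable from compound 2 to compound 3 expected to be no larger than the usual scatter. The estimate for compound 3 in this assay is 3000 nM, within a range from 800 nM to 20000 nM, most likely reported as a limit again.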

Compound 3, half-maximal inhibitory concentration: > 1000 nM
Compound 3: no number, only a limit; the forecaster's own chance of this, stated with the estimate: 80%; the middle value does not contradict the limit.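

In this assay compound 3 gives > 1000 nM, which is a limit of the assay and not a number. No new step can be read from compound 3 to compound 1 or compound 2, as all three share one limit: the limit of > 1000 nM in this assay, at which 3 of the 3 values shown sit. The compounds shown leave open how strongly each one inhibits, and whether fluoro in place of methyl changes that at all.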